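Phenyl in Place of Thiophene: What to Expect

The compounds below may be only part of what the source reports. "The series", "measured", "known", "first", "only" and "open" are said of these compounds alone.

Compound 1, `CC1CCCc2c1[nH]c(=O)c(C#N)c2-c1cccn1C`, gives > 100000 nM in a functional assay on IGROV-1 cells (Homo sapiens) for inhibition, read by sulforhodamine B assay, with a stated time of 48 h (on this read-out lower numbers stand for stronger inhibition of growth and higher numbers for weaker inhibition of growth), which is a limit of the assay rather than a number.
Compound 2, `Cn1cccc1-c1cc(-c2cccs2)nc(N)c1C#N`, gives > 100000 nM in this assay, again a limit and not a number.

Compound 2 therefore stands at the upper edge of what this measurement can report, and it is not alone there: the limit of > 100000 nM in this assay, at which 2 of the 2 values shown sit. Among the compounds with values here, no single step between two measured compounds is available, so the size of the change from one structure to another cannot be read off directly.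

Compound 3, `Cn1cccc1-c1cc(-c2ccccc2)nc(N)c1C#N`, is the next compound to be tested. It differs from compound 2 in one place: phenyl in place of thiophen-2-yl on an aromatic carbon. Both measured compounds sit at the limit, which gives no foothold for a large movement in either direction. The step expected from this change is a number no higher from compound 2 to compound 3 (the limit leaves the size open), that is, nothing beyond the usual scatter. For compound 3 the estimated value in this assay is 100000 nM, with a range from 30000 nM to 300000 nM, and a strong chance that the assay again reports only a limit.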

Compound 3, concentration for 50% growth inhibition: > 100000 nM
Compound 3: no number, only a limit (the forecaster's own chance of this, stated with the estimate: 75%); the middle value sits exactly at the limit.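

Compound 3 gives > 100000 nM in this assay, again a limit of the assay and not a number. Within the data shown here, compound 2 also stands at a limit, and no step between compound 2 and compound 3 can be read. The compounds shown leave open whether any group on the shared core brings growth inhibition into the measurable range, with every value at one edge: the limit of > 100000 nM in this assay, at which 3 of the 3 values shown sit.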